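This account rests on a few compounds, and the source may have more. Where it says the series, first, only, none or still open, it means among the compounds named here.

Measured compounds:
- Compound 1 `CC(C)(C)OC(=O)N1CCc2c(sc(NC(=O)Nc3ccc(Cl)cc3)c2C(N)=O)C1`: > 25000 nM, a limit of the assay and not a number.
- Compound 2 `NC(=O)c1c(NC(=O)Nc2ccc(Cl)cc2)sc2c1CCN(CC1CCCC1)C2`: 1830 nM.
- Compound 3 `NC(=O)c1c(NC(=O)Nc2ccc(Cl)cc2)sc2c1CCN(CCCNC(=O)CCc1cccnc1)C2`: 470 nM.

These values come from a functional assay (strain AB) with Danio rerio as the target, read by microscopy, with a stated time of 1 h; a higher number here means that more compound is needed for the effect, a lower number that less compound is needed. Compound 3 has the lowest number of the two exact values, clearly lower than compound 2.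

Compound 4 `CC(C)(C)OC(=O)CCCCN1CCc2c(sc(NC(=O)Nc3ccc(Cl)cc3)c2C(N)=O)C1` has (tert-butoxycarbonyl)methyl in place of ((2-(pyridin-3-yl)ethyl)carbonyl)amino on a saturated chain carbon, three bonds along the chain from an amine nitrogen in a ring.

Within the data shown here, one measured step bears on this, and it is large: an at least 13-fold lower number from compound 1 to compound 2 (1.13 log units; beyond the scatter). There, tert-butoxycarbonyl left an amine nitrogen in a ring. In compound 4 that group returns, but at the end of a chain, so only a moderate rise is expected in this assay.

The expected change is a 3.8-fold higher number from compound 3 to compound 4 (0.58 log units; beyond the scatter).

For compound 4 the estimated value is 1800 nM, with an expected range of 500 nM to 9000 nM.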

Compound 4, half-maximal effective concentration: 710 nM
Estimate against measurement, compound 4: 2.5-fold (0.40 log units) above; the range from low to high includes it.
By their numbers in this assay, from the lowest: compounds 3 and 4 (each within the scatter of the next); then compound 2. At a limit, above all of these: compound 1.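

With (tert-butoxycarbonyl)methyl in place of ((2-(pyridin-3-yl)ethyl)carbonyl)amino, the step is a 1.5-fold higher number from compound 3 to compound 4 (0.18 log units; within the scatter), so the pyridine ring and amide hydrogen of the leaving group are not required for an effect at this chain carbon. Carried at the end of a chain, the tert-butoxycarbonyl group still gives an effect, with a 2.6-fold lower number from compound 2 to compound 4 (0.41 log units; beyond the scatter) and an at least 35-fold lower number from compound 1 to compound 4 (1.54 log units; beyond the scatter). Compound 1 is held at a limit, not a number: the limit of > 25000 nM in this assay, at which 1 of the 4 values shown sits.

On these data alone, what remains open is how much the tert-butoxycarbonyl group itself contributes. A carboxylic acid or an amine at the end of this chain, or a longer chain, would help to show this.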